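From (chloromethyl)carbonyl to dimethylsulfamoyl on the shared core

A few compounds are considered here, and "the series" means these few. Any claim that something is new, unique, unknown or untested is made for them only; others in the source may bear on it.

In a functional assay on HCT-116 cells (Homo sapiens) for cytotoxicity, read by sulforhodamine B assay, with a stated time of 48 h (a lower number here means a stronger inhibitor, a higher number a weaker inhibitor), three compounds sharing one core have been measured. Compound 1 `CC(=O)n1nc(NC(=O)c2ccccc2)c2c1CN(C(=O)C1CCC(C)CC1)C2` gives 12200 nM, compound 2 `CC(=O)n1nc(NC(=O)c2ccccc2)c2c1CN(C(=O)c1cccc(Cl)c1)C2` gives 17400 nM, and compound 3 `CC(=O)n1nc(NC(=O)c2ccccc2)c2c1CN(C(=O)CCl)C2` gives 4100 nM, the lowest of the three numbers.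

The step under consideration leads from compound 3 to compound 4 `CC(=O)n1nc(NC(=O)c2ccccc2)c2c1CN(S(=O)(=O)N(C)C)C2`: dimethylsulfamoyl in place of (chloromethyl)carbonyl on an amine nitrogen in a ring. In words, this is dimethylsulfamoyl in place of (chloromethyl)carbonyl on an amine nitrogen in a ring.

For the measured compounds named here, three measured steps bear on this site, all of them exchanges on a carbonyl carbon: a 1.4-fold higher number from compound 1 to compound 2 (0.15 log units; within the scatter), a 3.0-fold lower number from compound 1 to compound 3 (0.47 log units; beyond the scatter) and a 4.2-fold lower number from compound 2 to compound 3 (0.63 log units; beyond the scatter). The first lies within the scatter, and the other two are modest but beyond it. Compound 3 therefore stands apart from the other two, although three compounds make a thin basis. Going by the values given here, no measured compound carries a dimethylsulfamoyl group, so the data offer no direct guide to it.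

Compound 4 gives up the group found only in compound 3, so a return towards the numbers of the other two is expected. In this assay the expected size of the change is a 2.7-fold higher number from compound 3 to compound 4 (0.43 log units; beyond the scatter). For compound 4 the estimate is 11000 nM, with an expected range of 4500 nM to 30000 nM.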

Compound 4, half-maximal inhibitory concentration: 35300 nM
Estimate against measurement, compound 4: 3.2-fold (0.51 log units) below; measured number outside the range, above it.
By their numbers in this assay, from the lowest: compound 3; then compounds 1 and 2 (each within the scatter of the next); then compound 4.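

In this assay dimethylsulfamoyl on the amine nitrogen in a ring does more than give up the low number of compound 3: the change is an 8.6-fold higher number from compound 3 to compound 4 (0.93 log units; beyond the scatter), and the comparison with the other two is a 2.0-fold higher number from compound 2 to compound 4 (0.31 log units; beyond the scatter) and a 2.9-fold higher number from compound 1 to compound 4 (0.46 log units; beyond the scatter), which leaves compound 4 the weakest of the four. The position therefore spans a wider range than the exchanges on a carbonyl carbon alone showed, and the three compounds with a carbonyl on this nitrogen all give lower numbers than compound 4, although that split rests on a single dimethylsulfamoyl example and no compound shown goes against it. No measurement at hand bears on the cause of these differences.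

On these data alone, whether the rise follows the sulfonyl link itself or the dimethylamino end of the group stays open, and a methanesulfonyl group on the same nitrogen would separate the two. Also open, as far as these compounds go, is how much of the low number of compound 3 belongs to its chlorine, which a plain acetyl group in place of (chloromethyl)carbonyl would test.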